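Methylcarbamoyl analogue of compound 2: expected inhibition

The source may hold more compounds than are shown below. What is called first, only, known or untested is meant among the compounds shown, and "the series" means these compounds.

Compound 1 `COc1cc(CNc2cc(Br)cc3[nH]ncc23)c([N+](=O)[O-])cc1OC` and compound 2 `O=C(O)CNc1cccc(CNc2cc(C(F)(F)F)cc3[nH]ncc23)c1` share a core. In an assay for inhibition of Indoleamine 2,3-dioxygenase 1 (Homo sapiens), with stated times of 10 min and 60 min, tested at 100 uM (a lower number here means a weaker effect, a higher number a stronger effect of the compound at the concentration tested), compound 1 gives 79%. In this assay compound 2 gives 8%, the lowest of the two numbers and beyond the scatter from compound 1. Among the measured compounds shown here, no step between measured compounds differing in one place is known. Compound 3 `CNC(=O)c1cccc(CNc2cc(C(F)(F)F)cc3[nH]ncc23)c1` differs from compound 2 by methylcarbamoyl in place of (carboxymethyl)amino on an aromatic carbon. With nothing measured for a change of this kind, the step is expected to be small, upward if at all, or none beyond the scatter: a number 7 percentage points higher from compound 2 to compound 3 (within the scatter). Compound 3 is expected to give 15% in this assay, between 0% and 40%.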

Compound 3, a percentage reported as inhibition, at one concentration (the size of the read-out at that concentration, not a potency): 46%
For compound 3 the middle estimate is 31 percentage points below the measured one, and the stated range ends below it.
By their numbers in this assay, from the lowest: compound 2; then compound 3; then compound 1.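

In this assay, among the compounds shown here, methylcarbamoyl in place of (carboxymethyl)amino gives a number 38 percentage points higher from compound 2 to compound 3 (beyond the scatter) and is the only one-place step available. The read-out is therefore sensitive to the group on this aromatic carbon, meta to a large group, which the two earlier compounds, differing in more than one place, could not show. No measurement on hand explains the step. Open, going by these compounds, is how a carboxylic acid directly on the ring, a primary amide or a longer chain on the amide nitrogen would compare with methylcarbamoyl at this position.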